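The source may report more compounds than this note shows. Statements on the series, on what has been measured and on what is new or still open speak of the compounds shown alone.

Compounds measured in an in vitro assay on CHO cells for displacement of a labelled ligand from Bombesin receptor subtype-3 (Homo sapiens), read by scintillation counting, with a stated time of 2 h; a lower number here means a stronger inhibitor, a higher number a weaker inhibitor: compound 1 `CCC(C)(C)Cc1c[nH]c(CCc2ccc(-n3ccnn3)cc2)n1` gives 390 nM; compound 2 `CCC(C)(C)Cc1c[nH]c(CCc2ccc(-c3cnccn3)cc2)n1` gives 51 nM.

Compound 2 holds the lowest of the two numbers in this assay, with compound 1 the nearest at a 7.6-fold lower number from compound 1 to compound 2 (0.88 log units; beyond the scatter). Compound 3 `CCC(C)(C)Cc1c[nH]c(CCc2ccc(-c3ccccc3C(=O)O)cc2)n1` differs from compound 2 by 2-carboxyphenyl in place of pyrazin-2-yl on an aromatic carbon. For the measured compounds named here, the one step known, from compound 1 to compound 2, exchanges the same aromatic substituent and was modest; it shows this position tolerates change without settling the direction here. A step of similar size, toward a higher number, is expected: a 3.9-fold higher number from compound 2 to compound 3 (0.59 log units; beyond the scatter). Compound 3 is estimated at 200 nM, within 50 nM to 800 nM.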

Compound 3, half-maximal inhibitory concentration: 11 nM
For compound 3 the middle estimate is 18-fold (1.26 log units) above the measured one; measured number below the stated range.
By their numbers in this assay, from the lowest: compound 3; then compound 2; then compound 1.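

In this assay, the exchange of pyrazin-2-yl for 2-carboxyphenyl gives a 4.6-fold lower number from compound 2 to compound 3 (0.67 log units; beyond the scatter) and shows that this place, para to a large group, accepts a ring of carbon only bearing a carboxylic acid. The wider comparison gives a 35-fold lower number from compound 1 to compound 3 (1.55 log units; beyond the scatter) and places the three aromatic substituents in one order, with 2-carboxyphenyl ahead of both rings containing nitrogen. Going by these compounds, it remains open whether the carboxylic acid or the phenyl ring carries this step, and a plain phenyl, a methyl ester or a primary amide would separate the two. No supporting measurement bears on this step.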